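Amine-nitrogen substituent change in a tryptamine-piperidine series

This account rests on a few compounds, and the source may have more. Where it says the series, first, only, none or still open, it means among the compounds named here.

Three members of this series have a measured value in an assay on CHO cells for displacement of a labelled ligand from 5-hydroxytryptamine receptor 1D (Homo sapiens); on this read-out lower numbers stand for stronger inhibition and higher numbers for weaker inhibition. Compound 1 `c1ccc(C2CCCCN2C2CCN(CCCc3c[nH]c4ccc(-n5cnnc5)cc34)CC2)cc1` gives 1.9 nM in this assay. Compound 2 `OC[C@H](NC1CCN(CCCc2c[nH]c3ccc(-n4ccnc4)cc23)CC1)c1ccccc1` gives 0.7 nM. Compound 3 `c1ccc2c(c1)CCC2NC1CCN(CCCc2c[nH]c3ccc(-n4cnnc4)cc23)CC1` gives 8.9 nM, the highest number of the three; its nearest neighbour is compound 1, and compound 2 stands furthest from it, both gaps lying beyond the usual scatter. No pair of these compounds differs in a single place, so no direct step between measured compounds can be read off.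

Compound 4 `c1cncc(CNC2CCN(CCCc3c[nH]c4ccc(-n5cnnc5)cc34)CC2)c1` remains unmeasured. It differs from compound 3 in one place: (pyridin-3-yl)methyl in place of 2,3-dihydro-1H-inden-1-yl on an amine nitrogen. The group that enters is smaller and carries an acceptor where the leaving group carried none, while the attachment on the amine nitrogen is kept.

For the measured compounds named here, nothing among the measured compounds isolates this change. Compounds 1 and 2 show that quite different groups on this part of the molecule return low numbers, yet neither shares the entering group. For compound 4 the step of a 1.3-fold higher number from compound 3 to compound 4 (0.13 log units; within the scatter) is expected to stay within the scatter, with no clear direction. Compound 4 is therefore estimated at 12 nM in this assay, with a range from 3 nM to 50 nM.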

Compound 4, half-maximal inhibitory concentration: 35 nM
For compound 4 the middle estimate is 2.9-fold (0.46 log units) below the measured one; the measured number falls inside the stated range.
By their numbers in this assay, from the lowest: compound 2; then compound 1; then compound 3; then compound 4.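

Working notes on the amine nitrogen: the series now has its first single-place step in this assay, and replacing 2,3-dihydro-1H-inden-1-yl with (pyridin-3-yl)methyl gives a 3.9-fold higher number from compound 3 to compound 4 (0.59 log units; beyond the scatter). The change is modest but lies beyond the usual scatter, so the group on this amine nitrogen does affect the read-out, and this exchange moves the number in the weaker direction. The change removes the five-membered carbon ring, lowers the heavy-atom count of the group and introduces a hydrogen-bond acceptor, but nothing measured here shows which of these differences accounts for the step.

Still open, on these data alone, is whether the pyridine ring nitrogen contributes to the step at all: a benzyl group on the same amine nitrogen would separate that atom from the loss of the five-membered ring, while (pyridin-2-yl)methyl and (pyridin-4-yl)methyl would test where the ring nitrogen is tolerated. As far as these compounds go, it also remains open whether the same exchange would produce a step of similar size and direction on the core of compound 2.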